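Swapping 3-phenylpropyl for 2-phenylcyclopropyl on compound 2

The source may report more compounds than this note shows. Statements on the series, on what has been measured and on what is new or still open speak of the compounds shown alone.

Measured in an ADME assay on a cell-free system (plasma, Homo sapiens) for metabolic stability, tested at 1 uM; a lower number here means that the compound disappears faster, a higher number that the compound lasts longer:
- Compound 1 `C=CC(=O)NC1CCN(S(=O)(=O)c2ccc(C(=O)NCc3ccccc3)cc2)CC1`: > 6 h (a limit)
- Compound 2 `C=CC(=O)NC1CCN(S(=O)(=O)c2ccc(C(=O)NCCCc3ccccc3)cc2)CC1`: > 6 h (a limit)

Compound 2 gives > 6 h, which is a limit of the assay and not a number. Neither measured compound has a numerical value: the limit of > 6 h in this assay, at which 2 of the 2 values shown sit. Compound 3 `C=CC(=O)NC1CCN(S(=O)(=O)c2ccc(C(=O)N[C@@H]3C[C@H]3c3ccccc3)cc2)CC1` carries 2-phenylcyclopropyl in place of 3-phenylpropyl on an amide-type nitrogen. For the measured compounds named here, the only measured step that bears on this change is a step that the two limits leave unreadable from compound 1 to compound 2, so it offers no size to carry over. No step beyond the scatter is therefore expected in this assay, and no direction can be given. The estimated step is a step that the limit leaves unreadable from compound 2 to compound 3. Compound 3 is expected at 9 h, with an estimated range from 4 h to 18 h.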

Compound 3, half-life: > 6 h
Compound 3: no number, only a limit; the forecaster's own chance of this, stated with the estimate: 75%; the middle value does not contradict the limit.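

In this assay compound 3 gives > 6 h, a limit of the assay and not a number. No step among compound 1, compound 2 and compound 3 can be read: the limit of > 6 h in this assay, at which 3 of the 3 values shown sit.

As far as these compounds go, whether 2-phenylcyclopropyl and 3-phenylpropyl on the amide-type nitrogen differ in half-life at all stays open.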